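A Methoxy Step Repeated on a Second Core

A few compounds are considered here, and "the series" means these few. Any claim that something is new, unique, unknown or untested is made for them only; others in the source may bear on it.

The study concerns four compounds built on two closely related cores. Compound 1, `COC1Cc2c(csc2-c2ccccc2)C2(CCN(Cc3ccccc3)CC2)O1`, and compound 2, `COc1ccc(-c2scc3c2CC(OC)OC32CCN(Cc3ccccc3)CC2)cc1`, share one core; compound 3, `COC1Cc2cc(-c3ccccc3)sc2C2(CCN(Cc3ccccc3)CC2)O1`, and compound 4, `COc1ccc(-c2cc3c(s2)C2(CCN(Cc4ccccc4)CC2)OC(OC)C3)cc1`, share the other. The two cores have the same atoms joined differently, and the difference between them is not broken down here.

In an assay on membranes from brain for displacement of a labelled ligand from Sigma non-opioid intracellular receptor 1 (Cavia porcellus), read by scintillation counting, with a stated time of 120 min (a lower number here means a stronger inhibitor, a higher number a weaker inhibitor), compound 1 gives 1 nM. Compound 2 differs from compound 1 by methoxy in place of hydrogen on an aromatic carbon, and in this assay compound 2 gives 2.2 nM, so that the change made a 2.2-fold higher number from compound 1 to compound 2 (0.34 log units; beyond the scatter). Compound 3 gives 16 nM in this assay, the highest number of the three measured compounds, beyond the scatter from both compound 1 and compound 2.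

Compound 4 differs from compound 3 by methoxy in place of hydrogen on an aromatic carbon. This is the same change as the one separating compound 1 and compound 2, at a place described in the same words, and it occurs twice among the compounds shown. Going by the values given here, because the only measured instance of it gave a 2.2-fold higher number from compound 1 to compound 2 (0.34 log units; beyond the scatter), a step of similar size is expected, a 2.2-fold higher number from compound 3 to compound 4 (0.34 log units; beyond the scatter), although that expectation rests on a single precedent made on a different core. Compound 4 is accordingly estimated at 35 nM in this assay, with a likely range from 15 nM to 80 nM.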

Compound 4, inhibition constant: 56 nM
For compound 4 the middle estimate is 1.6-fold (0.20 log units) below the measured one; low and high end bracket the measured number.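

In this assay, the change from phenyl to 4-methoxyphenyl on the core of compound 3 gave a 3.5-fold higher number from compound 3 to compound 4 (0.54 log units; beyond the scatter), a weakening in the same direction as the one seen on the core of compound 1. Set side by side, the two steps do not differ, so in this series the change carried over from one core to the other with its direction and its size intact: the same change on two cores in this assay, a 2.2-fold higher number (0.34 log units; beyond the scatter) from compound 1 to compound 2 and a 3.5-fold higher number (0.54 log units; beyond the scatter) from compound 3 to compound 4, 1.6-fold (0.20 log units) apart, within the scatter of two such steps. Going by these compounds alone, this agreement rests on only two pairs of compounds, however, so it shows neither that the step would hold on any further core nor why methoxy in this place weakens the number on both cores.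

The compounds shown leave open what other groups would do at the same place on the six-membered aromatic ring, such as a hydroxyl, a fluorine, an amine or a longer chain like ethoxy, and whether those steps would also match across the two cores. They also leave open whether methoxy would give a similar step elsewhere on that ring, since both pairs carry it para to a large group.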